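The source may report more compounds than this note shows. Statements on the series, on what has been measured and on what is new or still open speak of the compounds shown alone.

Measured so far:
compound 1 `CC(C)Cn1cc(-c2ccnc3[nH]c(C4CCN(CC(=O)N(C)C)CC4)cc23)ccc1=O`: 21 uL/min
compound 2 `CC(C)n1cc(-c2ccnc3[nH]c(C4CCN(CC(=O)N5CCCCC5)CC4)cc23)ccc1=O`: > 300 uL/min

Going by the values given here, in an ADME assay on microsomes from liver (Homo sapiens) for metabolic stability (on this read-out higher numbers stand for fast clearance and lower numbers for slow clearance), compound 1 gives 21 uL/min, the only numerical value in the set. Compound 2 reaches only (the limit of > 300 uL/min in this assay, at which 1 of the 2 values shown sits), a limit rather than a number. Among the compounds with values here, no step between measured compounds is available.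

Compound 3 `CN(C)C(=O)CN1CCC(c2cc3c(-c4ccc(=O)n(C5CCC5)c4)ccnc3[nH]2)CC1` differs from compound 1 by cyclobutyl in place of isobutyl on an aromatic nitrogen. Cyclobutyl in place of isobutyl keeps the same count of heavy atoms. With nothing measured for such a change, compound 3 is expected to stay close to compound 1, with the step of a 1.2-fold higher number from compound 1 to compound 3 (0.08 log units; within the scatter) expected to lie within the usual scatter. Compound 3 is estimated at 25 uL/min, within 10 uL/min to 70 uL/min.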

Compound 3, intrinsic clearance in a liver preparation (reported as CLH), per the amount of preparation that the assay uses: < 3 uL/min
Compound 3 was reported as a limit (the forecaster's own chance of this, stated with the estimate: 5%); at least 8.3-fold (0.92 log units) between middle value and limit.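

In this assay the nitrogen substituent alone moves the read-out: cyclobutyl in place of isobutyl on an aromatic nitrogen gives an at least 7.0-fold lower number from compound 1 to compound 3 (0.84 log units; beyond the scatter) with the count of heavy atoms unchanged. Going by these compounds alone, this is the first matched step, and it shows that closing the four carbons into a ring matters at this position. Going by these compounds, compound 3 gives a limit and not a number, so the full size of the step stays unknown: the limit of < 3 uL/min in this assay, at which 1 of the 3 values shown sits.

On these data alone, whether a cyclopropyl or cyclopentyl group, or an oxetane ring, on this nitrogen would give the same result remains open. Also open, as far as these compounds go, is whether cyclobutyl would hold its effect with the piperidine amide of compound 2 in place of the dimethylamide.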